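Swapping the ester for an amide on the benzylic carbon

This account rests on a few compounds, and the source may have more. Where it says the series, first, only, none or still open, it means among the compounds named here.

Measured so far:
compound 1, `CCC(=O)OCc1ccc2oc(=O)c(C(=O)Oc3cccc(Br)c3)cc2c1`, 21.3%
compound 2, `CCCCCCC(=O)OCc1ccc2oc(=O)c(C(=O)Oc3cccc(Br)c3)cc2c1`, 36%
compound 3, `CC(C)(C)C(=O)OCc1ccc2oc(=O)c(C(=O)Oc3cccc(Br)c3)cc2c1`, 23.6%

These three compounds share one core and differ only in the acyl group of the ester on the saturated chain carbon bound to an aromatic carbon. In a functional assay on HT-1080 cells (Homo sapiens), read by transwell migration, with a stated time of 24 h, tested at 10 uM (a higher number here means a weaker effect of the compound at the concentration tested, a lower number a stronger effect), compound 3 stands second highest of the three numbers: its nearest neighbour is compound 1, with a gap that lies within the scatter, and its furthest is compound 2, whose step is beyond the scatter.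

Compound 4, `CC(=O)NCc1ccc2oc(=O)c(C(=O)Oc3cccc(Br)c3)cc2c1`, differs from compound 3 as follows: acetamido in place of ((tert-butyl)carbonyl)oxy on a saturated chain carbon bound to an aromatic carbon.

The measured steps show what changing the acyl group does: a number 14.7 percentage points higher from compound 1 to compound 2 (beyond the scatter), and a number 12.4 percentage points lower from compound 2 to compound 3 (beyond the scatter), while a number 2.3 percentage points higher from compound 1 to compound 3 (within the scatter). The shift to an amide is not covered by any measured step, and the acetamido group is small like the acyl groups of compounds 1 and 3. The number for compound 4 is therefore expected near compound 3, with a number 1.4 percentage points higher from compound 3 to compound 4 (within the scatter). Compound 4 is estimated at 25%, within 10% to 45%.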

Compound 4, a percentage reported as activity, at one concentration (the size of the read-out at that concentration, not a potency): 27.1%
Beside the measured number, compound 4's estimate is 2.1 percentage points below it; low and high end bracket the measured number.
By their numbers in this assay, from the lowest: compounds 1, 3, 4 and 2 (each within the scatter of the next, the first and the last beyond it).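

Swapping the ester link for an amide on the saturated chain carbon bound to an aromatic carbon leaves the read-out in this assay unmoved beyond the scatter, even though the amide hydrogen brings in a hydrogen-bond donor that the esters lack: a number 3.5 percentage points higher from compound 3 to compound 4 (within the scatter) and a number 5.8 percentage points higher from compound 1 to compound 4 (within the scatter). Compound 4 also stays close to the hexyl ester, with a number 8.9 percentage points lower from compound 2 to compound 4 (within the scatter), so it cannot be told apart from any of the three esters, although compound 1 and compound 2 can be told apart from each other. Nothing shown here explains this closeness.

Acetamido changes both the link and the acyl group at once, so an acetoxy ester would be needed to separate the two changes. As far as these compounds go, how a longer chain on the amide, a free amine or a carboxylic acid would behave on this carbon also remains open.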